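Swapping methoxy for trifluoromethyl in a chalcone series

The source may hold more compounds than are shown below. What is called first, only, known or untested is meant among the compounds shown, and "the series" means these compounds.

Three chalcones have been tested in an ADME assay on MCF7-DOX cells (Homo sapiens) for cytotoxicity, read by MTT assay, with a stated time of 48 h; on this read-out higher numbers stand for weaker inhibition and lower numbers for stronger inhibition. Compound 1 `COc1ccc(/C=C/C(=O)c2c(OC)cc(OC)c(CC=C(C)C)c2O)cc1` gives 46900 nM in this assay, the second highest of the three numbers, and its gaps to both neighbours sit within the usual scatter. Compound 2 `COc1cc(OC)c(C(=O)/C=C/c2cccc(N3CCN(C(=O)OC(C)(C)C)CC3)c2)c(O)c1CC=C(C)C` gives 42600 nM, and compound 3 `COc1cc(O)c(C(=O)/C=C/c2cccc(N3CCN(C)CC3)c2)c(OC)c1` gives 62200 nM. All three numbers are high, so none of these compounds inhibits the cells strongly.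

Compound 4 `COc1cc(OC)c(C(=O)/C=C/c2ccc(C(F)(F)F)cc2)c(O)c1CC=C(C)C` has not yet been measured. It differs from compound 1 by trifluoromethyl in place of methoxy on an aromatic carbon. Going by the values given here, no measured pair shows what this change does here, so the expectation is a step of no more than the scatter, in either direction. For compound 4 the expected step is a 1.0-fold lower number from compound 1 to compound 4 (0.02 log units; within the scatter). The estimate for compound 4 is 45000 nM, between 20000 nM and 100000 nM.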

Compound 4, half-maximal inhibitory concentration: 73700 nM
The estimate for compound 4 lay 1.6-fold (0.21 log units) below the measured number; measured number inside the range.
By their numbers in this assay, from the lowest: compounds 2, 1, 3 and 4 (each within the scatter of the next).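

In this assay, going by these compounds alone, this is the first change in one place that can be read, and it gives a 1.6-fold higher number from compound 1 to compound 4 (0.20 log units; within the scatter). Replacing 4-methoxyphenyl with 4-(trifluoromethyl)phenyl therefore does not clearly move the number, so at this position on the ring the two groups cannot be told apart. Nothing at hand explains the step.

Going by these compounds, whether an amine or a carboxylic acid at the same position would move the number beyond the scatter remains open. So does whether any group there could bring these high numbers down substantially.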